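Swapping a Sulfone for a Sulfonamide on the Aryl Ring

This account rests on a few compounds, and the source may have more. Where it says the series, first, only, none or still open, it means among the compounds named here.

Compound 1 `CNc1nc(NCCCN(C)C)c2sc(-c3ccc(N)cc3)cc2n1`: 12.5 ug/mL
Compound 2 `CNc1nc(NCCCN(C)C)c2sc(-c3ccc(S(C)(=O)=O)cc3)cc2n1`: 25 ug/mL

Within the data shown here, in a physicochemical assay for solubility, in phosphate buffer, at pH 6.5 (on this read-out lower numbers stand for lower solubility and higher numbers for higher solubility), compound 2 gives 25 ug/mL, the higher of the two numbers measured so far. Compound 1 gives 12.5 ug/mL, and the step of a 2.0-fold higher number from compound 1 to compound 2 (0.30 log units; within the scatter) falls within the scatter, so the two compounds cannot be told apart on this read-out. Compound 3 `CNc1nc(NCCCN(C)C)c2sc(-c3ccc(NS(C)(=O)=O)cc3)cc2n1` has not yet been measured. It differs from compound 2 in one place: methanesulfonamido in place of methylsulfonyl on an aromatic carbon. Among the measured compounds shown here, only one measured step bears on this position, a 2.0-fold higher number from compound 1 to compound 2 (0.30 log units; within the scatter), and it concerns a different exchange at the same aromatic carbon; no measured pair swaps methylsulfonyl for methanesulfonamido. For the measured compounds named here, since the one relevant step stayed within the scatter, the expected step of a 1.3-fold lower number from compound 2 to compound 3 (0.10 log units; within the scatter) is also small, with no direction beyond the scatter. Compound 3 is therefore estimated at 20 ug/mL, within a range from 8 ug/mL to 50 ug/mL.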

Compound 3, solubility: 25 ug/mL
The estimate for compound 3 lay 1.3-fold (0.10 log units) below the measured number; low and high end bracket the measured number.
By their numbers in this assay, from the lowest: compounds 1, 2 and 3 (each within the scatter of the next).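

At this aromatic carbon, this assay records no change at the digits printed from compound 2 to compound 3 (within the scatter) when methanesulfonamido replaces methylsulfonyl, even though methanesulfonamido carries a hydrogen-bond donor and methylsulfonyl carries none. Placing methylsulfonyl on the nitrogen of the amino group gives a 2.0-fold higher number from compound 1 to compound 3 (0.30 log units; within the scatter) and so also stays within the scatter, which means that amino, methylsulfonyl and methanesulfonamido cannot be told apart on this read-out. No supporting measurement is available to explain why these exchanges leave the number within the scatter.

Going by these compounds, whether a carboxylic acid, a morpholine or a longer chain on the sulfonyl group at this aromatic carbon would move the number beyond the scatter remains open. On these data alone, it is also open whether these same exchanges would read alike on a core carrying a different side chain.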